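The source may hold more compounds than are shown below. What is called first, only, known or untested is meant among the compounds shown, and "the series" means these compounds.

Measured so far in an assay on CHO cells for displacement of a labelled ligand from adenosine receptor A1 (Homo sapiens), read by scintillation counting, tested at 10 uM; on this read-out lower numbers stand for less inhibition and higher numbers for more inhibition at the one concentration tested (going by the name of the read-out):
- compound 1 `CC(C)(C)Cc1c(-c2ccc(F)cc2)sc(N)c1C(=O)c1ccc(Cl)cc1`: 1%
- compound 2 `CC(C)(C)Cc1c(/C=C/c2ccc(Cl)cc2)sc(N)c1C(=O)c1ccc(Cl)cc1`: 1%
- compound 3 `Cc1ccc(C(=O)c2c(CC(C)(C)C)csc2N)cc1`: 1%

For the measured compounds named here, compound 2 stands level with compounds 1 and 3; all three sit at the bottom of this assay, and the one measured step, no change at the digits printed from compound 1 to compound 2 (within the scatter), lay within the scatter. Compound 4 `CC(C)(C)Cc1c(-c2cn[nH]c2)sc(N)c1C(=O)c1ccc(Cl)cc1` is the next member of the series. Its change from compound 2 is 1H-pyrazol-4-yl in place of 2-(4-chlorophenyl)ethenyl on an aromatic carbon. Going by the values given here, only the step from compound 1 to compound 2 touches the same position, and it showed nothing; no measured step exchanges a phenyl-type group for a pyrazole, so the evidence is thin. The expectation is therefore a step of about a number 3 percentage points higher from compound 2 to compound 4 (within the scatter), no direction beyond the scatter. Compound 4 is estimated at 4%, with a range from 0% to 25%.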

Compound 4, a percentage reported as inhibition, at one concentration (the size of the read-out at that concentration, not a potency): 1%
Beside the measured number, compound 4's estimate is 3 percentage points above it; measured number inside the range.
By their numbers in this assay, from the lowest: compounds 1, 2, 3 and 4 (each within the scatter of the next).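

In this assay there is no change at the digits printed from compound 2 to compound 4 (within the scatter), and likewise no change at the digits printed from compound 1 to compound 4 (within the scatter). On this aromatic carbon, then, 1H-pyrazol-4-yl, with fewer heavy atoms and with a hydrogen-bond donor and acceptor that the groups it replaces lack, leaves the reading where those groups left it. Nothing available explains this flat result.

Still open, on these data alone, is whether an amine or a carboxylic acid on this carbon would move the reading. Also open, as far as these compounds go, is whether a longer chain in place of the neopentyl group would do so.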